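Swapping iodine for bromine in a halogenated aminophenyl series

The source may hold more compounds than are shown below. What is called first, only, known or untested is meant among the compounds shown, and "the series" means these compounds.

Compound 1, whose structure is `Nc1ccc(-c2nc3cc(F)ccc3s2)cc1I`, was tested in a functional assay on T47D cells (Breast, Homo sapiens) for inhibition (on this read-out higher numbers stand for weaker inhibition of growth and lower numbers for stronger inhibition of growth), and gave 130 nM. Two other members of the same series are known. Compound 3, `Cc1cc(-c2nc3cccc(F)c3s2)ccc1N`, gave 20 nM in this assay, a number that is lower than that of compound 1 by more than the scatter of repeated measurements. Compound 2, `Nc1ccc(-c2nc3ccc(F)cc3s2)cc1Cl`, has in this assay only this entry: no result reported. On the numbers available, compound 1 therefore stands as the highest of the two measured values, meaning the weaker of the two at slowing growth of these cells.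

Compound 4, `Nc1ccc(-c2nc3cc(F)ccc3s2)cc1Br`, differs from compound 1 in a single place: bromo in place of iodo on an aromatic carbon. Both groups are single heavy atoms without ring, donor, acceptor or charge, so the change is small in count. Among the measured compounds shown here, no pair of measured compounds differs in this way alone, so no measured step guides the expectation directly. For a swap of this kind, a step of a 1.2-fold higher number from compound 1 to compound 4 (0.09 log units; within the scatter) is expected, which stays within the usual scatter and points, if anywhere, toward a slightly higher number.

Compound 4 is estimated to give 160 nM in this assay, with a likely range from 60 nM to 420 nM.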

Compound 4, concentration for 50% growth inhibition: 20 nM
Beside the measured number, compound 4's estimate is 8.0-fold (0.90 log units) above it; measured number outside the range, below it.
By their numbers in this assay, from the lowest: compounds 3 and 4 (each within the scatter of the next); then compound 1.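

Replacing iodo with bromo on an aromatic carbon ortho to an amino group exchanges one heavy atom for another, with no ring, donor, acceptor or charge involved, yet in this assay this change brings a 6.5-fold lower number from compound 1 to compound 4 (0.81 log units; beyond the scatter) and that step lies beyond the scatter. The earlier compounds shown here could not show this, since none of them formed a pair differing in one place; the new pair shows that, with the rest of compound 1 unchanged, the identity of the halogen at this position alone can move the number toward stronger inhibition of growth. No measurement is available that would explain why this single exchange has such an effect.

As far as these compounds go, a single step between two halogens gives no trend, so it remains open how a hydrogen, a methoxy group or a nitrile would fare at the same place on the core of compound 1. Also open, from the compounds shown here alone, is whether the exchange of iodo for bromo would bring a step of similar size on a different core, or in cells other than these.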